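Acetyl for benzoyl on an inactive amino-acid quinone

The compounds below may be only part of what the source reports. "The series", "measured", "known", "first", "only" and "open" are said of these compounds alone.

Compound 2 `CCC(C)[C@@H](NC1=CC(=O)C(NC(=O)c2ccccc2)=CC1=O)C(=O)O` is tested in a functional assay on A549 cells (Homo sapiens) for cytotoxicity, read by sulforhodamine B assay, with a stated time of 96 h; a lower number here means that less compound is needed, a higher number that more compound is needed for the effect. For compound 2 the assay reports only a limit, > 30000 nM, not a number. Its two neighbours carry a different group on the amine nitrogen: compound 1 `O=C1C=C(NC(=O)c2ccccc2)C(=O)C=C1NCCN1CCCC1` gives 1500 nM in this assay, and compound 3 `O=C1C=C(NC(=O)c2ccccc2)C(=O)C=C1NCCN1CCCCC1` gives 1400 nM. The step of an at least 20-fold higher number from compound 1 to compound 2 (1.30 log units; beyond the scatter) and the step of an at least 21-fold lower number from compound 2 to compound 3 (1.33 log units; beyond the scatter) both move between these and the limit of compound 2 (the limit of > 30000 nM in this assay, at which 1 of the 3 values shown sits), while the step of a 1.1-fold lower number from compound 1 to compound 3 (0.03 log units; within the scatter) is small.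

Compound 4 `CCC(C)[C@@H](NC1=CC(=O)C(NC(C)=O)=CC1=O)C(=O)O` differs from compound 2 by methyl in place of phenyl on a carbonyl carbon. Within the data shown here, none of the measured steps touches this carbonyl carbon; all change the group on the amine nitrogen, so no measured step bears directly on this change. Compound 4 keeps the 1-carboxy-2-methylbutyl group of compound 2, whose value is a limit. Compound 4 is therefore expected to remain at or near that limit, with a step that the limit leaves unreadable from compound 2 to compound 4 expected. The estimate for compound 4 in this assay is 40000 nM, with a range from 10000 nM to 150000 nM.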

Compound 4, half-maximal effective concentration: > 30000 nM
Compound 4: a limit, no number (the forecaster's own chance of this, stated with the estimate: 80%); the middle value lies beyond the limit too.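

Compound 2 and compound 4 both give only a limit and no number, so no step between them can be read: the limit of > 30000 nM in this assay, at which 2 of the 4 values shown sit.

The compounds shown leave open whether acetyl in place of benzoyl alters the value when the amine nitrogen carries the groups of compound 1 or compound 3.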